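Urea versus furanamide on the shared core: predicting compound 4

The source may report more compounds than this note shows. Statements on the series, on what has been measured and on what is new or still open speak of the compounds shown alone.

Compound 1 `CC(=O)Nc1nn(-c2ccccc2)c(=O)c2ccccc12`, compound 2 `O=C(Nc1ccc(Cl)cc1)Nc1nn(-c2ccccc2)c(=O)c2ccccc12` and compound 3 `O=C(Nc1nn(-c2ccccc2)c(=O)c2ccccc12)c1ccco1` share one core and differ only at the carbonyl carbon. In an assay on CHO cells for displacement of a labelled ligand from adenosine receptor A3 (Homo sapiens), tested at 1 uM (a higher number here means more inhibition at the concentration tested (going by the name of the read-out), a lower number less inhibition), compound 1 gives 0%, compound 2 gives 13% and compound 3 gives 8%; compound 3 thus differs from both compound 1 and compound 2 only within the usual scatter. Compound 4 `Cc1ccc(NC(=O)Nc2nn(-c3ccccc3)c(=O)c3ccccc23)cc1` carries (4-methylphenyl)amino in place of furan-2-yl on a carbonyl carbon. Within the data shown here, two steps bear on this: a number 13 percentage points higher from compound 1 to compound 2 (beyond the scatter), and a number 5 percentage points lower from compound 2 to compound 3 (within the scatter), so returning to an arylamino group is expected to move the number little. Compound 4 is expected to give 13%, in the range 3% to 25%. The expected step of a number 5 percentage points higher from compound 3 to compound 4 (within the scatter) would stay within the scatter.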

Compound 4, a percentage reported as inhibition, at one concentration (the size of the read-out at that concentration, not a potency): 45%
The estimate for compound 4 lay 32 percentage points below the measured number; the whole stated range lies below it.
By their numbers in this assay, from the lowest: compounds 1, 3 and 2 (each within the scatter of the next, the first and the last beyond it); then compound 4.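

Methyl in place of chloro on an aromatic carbon gives a number 32 percentage points higher from compound 2 to compound 4 (beyond the scatter) in this assay, so a single substituent on the arylamino ring carries a large step that the earlier changes on the carbonyl carbon did not show. (4-Methylphenyl)amino in place of furan-2-yl gives a number 37 percentage points higher from compound 3 to compound 4 (beyond the scatter) and in place of methyl gives a number 45 percentage points higher from compound 1 to compound 4 (beyond the scatter) on that carbonyl carbon, so the arylamino group in compound 2 and compound 4 does not act as one interchangeable group. Nothing measured here accounts for the gain.

On these data alone, whether it is specific to methyl remains open. Ethyl, methoxy or an unsubstituted phenylamino group would test this.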